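A few compounds are considered here, and "the series" means these few. Any claim that something is new, unique, unknown or untested is made for them only; others in the source may bear on it.

Going by the values given here, the three compounds measured so far share one core and differ only in the aromatic ring carried on the aromatic nitrogen. Compound 1 `C=CC(=O)Nc1cc(Nc2ncc3ncn(-c4ccc(F)cc4)c3n2)c(OC)cc1N(C)CCN(C)C` bears a 4-fluorophenyl group, compound 2 `C=CC(=O)Nc1cc(Nc2ncc3ncn(-c4ccc(Cl)cc4)c3n2)c(OC)cc1N(C)CCN(C)C` a 4-chlorophenyl group and compound 3 `C=CC(=O)Nc1cc(Nc2ncc3ncn(-c4ccccc4Cl)c3n2)c(OC)cc1N(C)CCN(C)C` a 2-chlorophenyl group. In an ADME assay on HT-29 cells (Homo sapiens) for cytotoxicity, read by MTT assay, with a stated time of 72 h (on this read-out lower numbers stand for stronger inhibition and higher numbers for weaker inhibition), compound 1 gives 12000 nM, compound 2 gives 7690 nM and compound 3 gives 11300 nM. Compound 3 thus stands second highest of the three numbers, and every step among them is small: a 1.6-fold lower number from compound 1 to compound 2 (0.19 log units; within the scatter), a 1.1-fold lower number from compound 1 to compound 3 (0.03 log units; within the scatter) and a 1.5-fold higher number from compound 2 to compound 3 (0.17 log units; within the scatter). Compound 4 `C=CC(=O)Nc1cc(Nc2ncc3ncn(-c4ccccc4Br)c3n2)c(OC)cc1N(C)CCN(C)C` differs from compound 3 in one place: bromo in place of chloro on an aromatic carbon. Among the compounds with values here, the only measured step that swaps one halogen for another is a 1.6-fold lower number from compound 1 to compound 2 (0.19 log units; within the scatter), and the step of a 1.5-fold higher number from compound 2 to compound 3 (0.17 log units; within the scatter) is likewise within the scatter. Nothing here points to a shift beyond the scatter. For compound 4 the expected step is therefore a 1.1-fold lower number from compound 3 to compound 4 (0.05 log units; within the scatter). The estimate for compound 4 is 10000 nM, with a range from 4000 nM to 25000 nM.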

Compound 4, half-maximal inhibitory concentration: 16200 nM
For compound 4 the middle estimate is 1.6-fold (0.21 log units) below the measured one; measured number inside the range.
By their numbers in this assay, from the lowest: compounds 2, 3, 1 and 4 (each within the scatter of the next, the first and the last beyond it).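

Placing bromo instead of chloro on this aromatic carbon, ortho to a large group, gives a 1.4-fold higher number from compound 3 to compound 4 (0.16 log units; within the scatter) in this assay, so this halogen swap does not clearly change the number. Going by these compounds alone, the step of a 1.4-fold higher number from compound 1 to compound 4 (0.13 log units; within the scatter) also stays small, while a 2.1-fold higher number from compound 2 to compound 4 (0.32 log units; beyond the scatter) is the first step in this set to pass beyond the scatter, though only modestly. That larger step changes both the halogen and its place on the ring, and no measurement shown explains it.

Every compound shown carries a single halogen on this ring, so these results cannot show how the number would respond to a very different group there, such as an amine or a carboxylic acid. They also cannot separate the effect of the halogen from that of its place on the ring in the step that passes beyond the scatter.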